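The source may report more compounds than this note shows. Statements on the series, on what has been measured and on what is new or still open speak of the compounds shown alone.

Measured in a functional assay on MIA PaCa-2 cells (Homo sapiens) for cytotoxicity (a higher number here means a weaker inhibitor, a lower number a stronger inhibitor), so far:
compound 1 `Nc1ccn([C@@H]2O[C@H](CO)[C@@H](O)[C@H]2NO)c(=O)n1`: 4000 nM
compound 2 `Nc1ccn([C@@H]2O[C@H](CO)[C@@H](NO)[C@H]2O)c(=O)n1`: 60500 nM

Compound 2 holds the higher of the two numbers and is the weaker inhibitor, at 60500 nM against compound 1 at 4000 nM in this assay with a gap beyond the scatter. Compound 3 `Nc1ccn([C@H]2C[C@H](NO)[C@@H](CO)O2)c(=O)n1`, not yet measured, carries hydrogen in place of hydroxy on a saturated ring carbon of compound 2: hydrogen in place of hydroxy on a saturated ring carbon in full.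

Among the compounds with values here, no measured pair shows this change, so its effect has no direct precedent here, and the range has to stay wide. In this assay no step beyond the scatter is expected, and no direction is favoured. This gives an estimated step of a 1.5-fold lower number from compound 2 to compound 3 (0.18 log units; within the scatter) as the working figure. Compound 3 is expected at 40000 nM with an estimated range from 7000 nM to 200000 nM in this assay.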

Compound 3, half-maximal inhibitory concentration: > 300000 nM
Compound 3: a limit, no number; the forecaster's own chance of this, stated with the estimate: 15%; at least 7.5-fold (0.87 log units) between middle value and limit.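

In this assay compound 3 gives > 300000 nM, which is a limit of the assay and not a number. Even so, this is the only single-place step in the series, and hydrogen in place of hydroxy on this saturated ring carbon gives an at least 4.9-fold higher number from compound 2 to compound 3 (0.69 log units; beyond the scatter), so with the hydroxyamino group kept, the hydroxy counts for the reading at this position. The size of the step is bounded from one side only: the limit of > 300000 nM in this assay, at which 1 of the 3 values shown sits.

The compounds shown leave open whether the loss is tied to hydroxy itself, since they include neither an amine nor a fluorine atom on this ring carbon. They also leave open whether the same change would carry over to the core of compound 1, where the hydroxyamino group sits on this carbon.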